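The source may hold more compounds than are shown below. What is called first, only, known or untested is meant among the compounds shown, and "the series" means these compounds.

Of the compounds shown here, three built on one shared core have been measured in a functional assay on RT-112 cells (Homo sapiens) for antiproliferative activity, read by MTT assay, with a stated time of 72 h; a higher number here means a weaker inhibitor of growth, a lower number a stronger inhibitor of growth. Compound 1 `COc1cc(NC(=O)Nc2cccc3c(Nc4cc(OC)cc(OC)c4)ncnc23)cc(OC)c1` gives 366 nM, compound 2 `COc1cc(Nc2ncnc3c(NC(=O)Nc4ccc(C)cc4C)cccc23)cc(OC)c1` gives 1290 nM, and compound 3 `COc1cc(Nc2ncnc3c(NC(=O)Nc4ccccc4Cl)cccc23)cc(OC)c1` gives 356 nM. Compound 2 therefore stands highest of the three, making it the weakest growth inhibitor of the set, with compound 1 and compound 3 both well below it. Compound 4 `COc1cc(Nc2ncnc3c(NC(=O)Nc4cc(C)cc(C)c4)cccc23)cc(OC)c1` differs from compound 2 only in the ring carried on the amide-type nitrogen: 3,5-dimethylphenyl in place of 2,4-dimethylphenyl on an amide-type nitrogen.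

Among the compounds with values here, two measured steps bear on this change. The step of a 3.5-fold higher number from compound 1 to compound 2 (0.55 log units; beyond the scatter) shows that a 2,4-dimethylphenyl in place of a 3,5-dimethoxyphenyl raises the number, and the step of a 3.6-fold lower number from compound 2 to compound 3 (0.56 log units; beyond the scatter) shows that a 2-chlorophenyl in place of the 2,4-dimethylphenyl brings it back down. Both steps involve the 2,4-dimethylphenyl of compound 2. Compound 4 keeps the same atoms but arranges them as a 3,5-dimethylphenyl, the same substitution pattern as the 3,5-dimethoxyphenyl of compound 1. A drop back toward compound 1 is expected because of a 3.5-fold higher number from compound 1 to compound 2 (0.55 log units; beyond the scatter), though methyl groups are not methoxy groups, so the recovery need not be complete. The expected step is a 2.6-fold lower number from compound 2 to compound 4 (0.41 log units; beyond the scatter). Compound 4 is thus estimated at 500 nM, most likely between 200 nM and 1200 nM.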

Compound 4, concentration for 50% growth inhibition: 10100 nM
The estimate for compound 4 lay 20-fold (1.31 log units) below the measured number, outside the stated range (above it).
By their numbers in this assay, from the lowest: compounds 3 and 1 (each within the scatter of the next); then compound 2; then compound 4.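

Moving the same two methyl groups on the ring is far from a neutral change at this position: the atom count stays the same, yet there is a 7.8-fold higher number from compound 2 to compound 4 (0.89 log units; beyond the scatter) in this assay. Sharing its substitution pattern with compound 1 does not preserve its activity, since replacing 3,5-dimethoxyphenyl with 3,5-dimethylphenyl gives a 28-fold higher number from compound 1 to compound 4 (1.44 log units; beyond the scatter) and the groups carried in that pattern therefore matter as well as their placement. The 2-chlorophenyl ring also compares favourably, with a 28-fold higher number from compound 3 to compound 4 (1.45 log units; beyond the scatter) as the change to 3,5-dimethylphenyl is made, leaving compound 4 as the weakest growth inhibitor of the four.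

Nothing available here explains why these closely related rings give such different numbers. Still open, from the compounds shown here alone, is how the number would respond to a ring carrying an amine, a carboxylic acid or a longer alkyl chain on this amide-type nitrogen, and whether the steep change seen with the two methyl groups would recur with those groups.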